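Swapping chloro for methyl on the benzyl group of compound 1

This account rests on a few compounds, and the source may have more. Where it says the series, first, only, none or still open, it means among the compounds named here.

Measured compounds:
compound 1 `Cc1cc(N2CC[C@@H](C)[C@@H](N(C)c3ncnc4[nH]ccc34)C2)n2nc(SCc3ccc(Cl)cc3)nc2n1` with 26300 nM
compound 2 `C#CSc1nc2nc(C)cc(N3CC[C@@H](C)[C@@H](N(C)c4ncnc5[nH]ccc45)C3)n2n1` with 62100 nM
compound 3 `Cc1nc2nc(SCc3ccc(Cl)cc3)nn2c(N2CC[C@@H](C)[C@@H](N(C)c3ncnc4[nH]ccc34)C2)c1C` with > 100000 nM

In a functional assay on BGC-823 cells (Homo sapiens) for inhibition, read by MTT assay, with a stated time of 72 h (on this read-out higher numbers stand for weaker inhibition and lower numbers for stronger inhibition), compound 1 gives 26300 nM, the lowest of the two numbers shown. Compound 2 gives 62100 nM, and the step of a 2.4-fold higher number from compound 1 to compound 2 (0.37 log units; beyond the scatter) swaps the whole 4-chlorobenzyl group on sulfur for ethynyl. Compound 3 gives only a limit in this assay, > 100000 nM; the step of an at least 3.8-fold higher number from compound 1 to compound 3 (0.58 log units; beyond the scatter) puts a methyl onto the shared core, and the figure is bounded by the limit of > 100000 nM in this assay, at which 1 of the 3 values shown sits.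

Compound 4 `Cc1ccc(CSc2nc3nc(C)cc(N4CC[C@@H](C)[C@@H](N(C)c5ncnc6[nH]ccc56)C4)n3n2)cc1` is not yet measured. It differs from compound 1 by methyl in place of chloro on an aromatic carbon, a change confined to the 4-chlorobenzyl group, which stays in place. Neither measured step touches that position: one removes the benzyl group altogether and the other alters the core. Among the compounds with values here, the two steps therefore set no direct precedent, and both run toward higher numbers. With the benzyl group kept, a step no larger than the scatter in this assay is expected for compound 4, leaning if anything toward a somewhat higher number, a 1.3-fold higher number from compound 1 to compound 4 (0.12 log units; within the scatter). Compound 4 is thus estimated at 35000 nM, within a range of 12000 nM to 100000 nM.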

Compound 4, half-maximal inhibitory concentration: 69500 nM
The estimate for compound 4 lay 2.0-fold (0.30 log units) below the measured number; the measured number falls inside the stated range.
By their numbers in this assay, from the lowest: compound 1; then compounds 2 and 4 (each within the scatter of the next). At a limit, above all of these: compound 3.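

In this assay, the chloro on the 4-chlorobenzyl group proves not to be a silent position: methyl in its place, on an aromatic carbon para to a large group, gives a 2.6-fold higher number from compound 1 to compound 4 (0.42 log units; beyond the scatter) even though each group counts one heavy atom and neither has any hydrogen-bond donors or acceptors. The earlier compounds showed only the loss of the whole benzyl group, whereas 4-methylbenzyl on the sulfur now proves indistinguishable from ethynyl there, with a 1.1-fold higher number from compound 2 to compound 4 (0.05 log units; within the scatter) as the step, so among these compounds the benzyl group alone does not preserve the number of compound 1 and the chloro also counts. Nothing shown here explains why exchanging chloro for methyl has this result.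

From the compounds shown here alone, this position rests on a single pair of compounds, so it remains open whether a fluoro, methoxy, amine or carboxylic acid group in place of the chloro would give a number closer to that of compound 1 or that of compound 4. Also open, going by these compounds, is whether the same exchange would give a step of similar size on a different core.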